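Aryl swap on the triazole nitrogen of a spiro-oxindole series

The compounds below may be only part of what the source reports. "The series", "measured", "known", "first", "only" and "open" are said of these compounds alone.

Compound 1 `CCc1ccccc1-n1nncc1CN1C(=O)C2(C(C#N)=C(N)Oc3c(N)cc4nc5ccccc5nc4c32)c2ccccc21` carries a 2-ethylphenyl on an aromatic nitrogen of the shared core; in a functional assay on MCF7 cells (Homo sapiens) for antiproliferative activity, read by MTT assay, with a stated time of 48 h (on this read-out lower numbers stand for stronger inhibition and higher numbers for weaker inhibition), compound 1 gives 24600 nM. Compound 2 `COc1ccc(-n2nncc2CN2C(=O)C3(C(C#N)=C(N)Oc4c(N)cc5nc6ccccc6nc5c43)c3ccccc32)cc1` carries a 4-methoxyphenyl in that place. In this assay compound 2 reaches only the limit of the assay, > 50000 nM, so no number is known for it. The step of an at least 2.0-fold higher number from compound 1 to compound 2 (0.30 log units; that floor lies within the scatter) is thus only a floor, set by the limit of > 50000 nM in this assay, at which 1 of the 2 values shown sits. Compound 3 `Cc1ccc(-n2nncc2CN2C(=O)C3(C(C#N)=C(N)Oc4c(N)cc5nc6ccccc6nc5c43)c3ccccc32)cc1Cl` differs from compound 2 by 3-chloro-4-methylphenyl in place of 4-methoxyphenyl on an aromatic nitrogen. Among the measured compounds shown here, no measured step touches a 3-chloro-4-methylphenyl on that nitrogen, so the only guide is that compound 2 sits at the limit and compound 1 is itself weak. Compound 3 is therefore expected to stay near the weak end, with an expected step of an at least 1.2-fold lower number from compound 2 to compound 3 (0.09 log units; that floor lies within the scatter) that need not exceed the scatter. In this assay compound 3 is estimated at 40000 nM, with a range from 15000 nM to 100000 nM.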

Compound 3, half-maximal inhibitory concentration: > 50000 nM
Compound 3: only a limit was reported; the forecaster's own chance of this, stated with the estimate: 50%; at least 1.2-fold (0.09 log units) between middle value and limit.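

In this assay compound 3 gives > 50000 nM, which is a limit and not a number, so a second aryl group without the methoxy oxygen also yields no readable value at this nitrogen. Setting 3-chloro-4-methylphenyl in place of 2-ethylphenyl gives an at least 2.0-fold higher number from compound 1 to compound 3 (0.30 log units; that floor lies within the scatter), which, like the step to the 4-methoxyphenyl, is only a floor and so establishes no order among the three aryl groups. The step between the two compounds at the limit cannot be read, and the aryl swap among them stays unresolved: the limit of > 50000 nM in this assay, at which 2 of the 3 values shown sit.

Going by these compounds, it remains open how far compound 2 and compound 3 truly lie from compound 1. Also open, on these data alone, is whether an amine or a carboxylic acid on the phenyl ring, or a propyl chain in place of the ethyl, would give a readable value in this assay.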